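Furan to Thiophene on the Imino Amide Carbonyl

The compounds below may be only part of what the source reports. "The series", "measured", "known", "first", "only" and "open" are said of these compounds alone.

Measured compounds in a functional assay on the whole organism (strain CF-1) with Mus musculus as the target, in the writhing test, with a stated time of 15 min; a lower number here means that less compound is needed, a higher number that more compound is needed for the effect:
compound 1 `CC(=O)/N=C1\NC2(CCCCO2)CCS1` gives 3.1 mg/kg
compound 2 `Cc1ccc(C(=O)/N=C2\NC3(CCCCO3)CCS2)cc1` gives 60 mg/kg
compound 3 `O=C(/N=C1\NC2(CCCCO2)CCS1)c1ccco1` gives 42 mg/kg

Compound 3 stands second highest of the three numbers in this assay. Its nearest neighbour is compound 2, and the step of a 1.4-fold lower number from compound 2 to compound 3 (0.15 log units; within the scatter) lies within the scatter; its furthest is compound 1, and the step of a 14-fold higher number from compound 1 to compound 3 (1.13 log units; beyond the scatter) is large. Compound 4 `O=C(/N=C1\NC2(CCCCO2)CCS1)c1cccs1` has not yet been measured. It differs from compound 3 by the change (thiophen-2-yl in place of furan-2-yl on a carbonyl carbon).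

Among the compounds with values here, two steps bear on this change. The step of a 19-fold higher number from compound 1 to compound 2 (1.29 log units; beyond the scatter) and the step of a 14-fold higher number from compound 1 to compound 3 (1.13 log units; beyond the scatter) both show that replacing the methyl on the carbonyl carbon by an aromatic ring gives a much higher number. The step of a 1.4-fold lower number from compound 2 to compound 3 (0.15 log units; within the scatter), however, shows that exchanging one aromatic ring for another at that position leaves the number within the scatter. Since compound 4 keeps a five-membered aromatic ring with one hetero atom at the same place, the expected step of a 1.1-fold higher number from compound 3 to compound 4 (0.03 log units; within the scatter) is none beyond the scatter. Compound 4 is therefore estimated at 45 mg/kg, with a range from 20 mg/kg to 100 mg/kg.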

Compound 4, dose for half-maximal effect: 48 mg/kg
Compound 4: the middle estimate sits 1.1-fold (0.03 log units) below what was measured; low and high end bracket the measured number.
By their numbers in this assay, from the lowest: compound 1; then compounds 3, 4 and 2 (each within the scatter of the next).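

In this assay, the step of a 1.1-fold higher number from compound 3 to compound 4 (0.06 log units; within the scatter) shows that exchanging the oxygen of the five-membered aromatic ring for sulfur, with thiophen-2-yl in place of furan-2-yl on the carbonyl carbon, leaves the number within the scatter. The step of a 1.3-fold lower number from compound 2 to compound 4 (0.10 log units; within the scatter) extends this to a third aromatic group: thiophen-2-yl and 4-methylphenyl cannot be told apart at this position either. The step of a 15-fold higher number from compound 1 to compound 4 (1.19 log units; beyond the scatter) adds a third large step away from the methyl compound, so among these compounds all three aromatic groups stand apart from methyl, and none goes against this.

Nothing available explains the gap between methyl and the aromatic groups. Going by these compounds, whether an ethyl group or a longer chain on the carbonyl carbon stays close to methyl or close to the aromatic groups remains open.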